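The source may hold more compounds than are shown below. What is called first, only, known or untested is meant among the compounds shown, and "the series" means these compounds.

Working notes on the series followed in a functional assay on MIA PaCa-2 cells (Homo sapiens) for cytotoxicity, read by fluorescence, with a stated time of 48 h; on this read-out higher numbers stand for an effect only at larger amounts of compound and lower numbers for an effect already at smaller amounts. Compound 1 `CC(C)=CCC/C(C)=C/CC/C(C)=C/CSC[C@H](NC(=O)CCCCCN1CCN(C)CC1)C(=O)NC1CC1` gives 10400 nM, the lowest of the two numbers recorded here. Compound 2 `CC(C)=CCC/C(C)=C/CC/C(C)=C/CSC[C@H](NC(=O)CCCCCN1CCCC1)C(=O)N1CCCCC1` gives 12400 nM; the gap to compound 1 lies within the scatter, so the two cannot be ranked against each other. Compound 3 `CC(C)=CCC/C(C)=C/CC/C(C)=C/CSc1ccccc1C(N)=O` returns only a limit, (the limit of > 20000 nM in this assay, at which 1 of the 3 values shown sits), and reads > 20000 nM. Among the measured compounds shown here, no two measured compounds differ in a single place, so no measured step is available to calibrate a change.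

Compound 4 `CC(C)=CCC/C(C)=C/CC/C(C)=C/CSC[C@H](NC(=O)CCCCCN1CCN(C)CC1)C(=O)NC1CCCCC1` differs from compound 1 at the terminal amide: cyclohexyl in place of cyclopropyl on an amide-type nitrogen. For the measured compounds named here, nothing among the measured compounds tests this kind of change, so the expectation rests on compound 1 at 10400 nM as the anchor. The step of a 1.3-fold lower number from compound 1 to compound 4 (0.11 log units; within the scatter) is expected to remain within the scatter, with a slight lean toward a lower number left open. Compound 4 is estimated at 8000 nM, within a range from 3000 nM to 22000 nM.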

Compound 4, half-maximal effective concentration: 5900 nM
Compound 4: the middle estimate sits 1.4-fold (0.13 log units) above what was measured; measured number inside the range.
By their numbers in this assay, from the lowest: compounds 4, 1 and 2 (each within the scatter of the next, the first and the last beyond it). At a limit, above all of these: compound 3.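

In this assay, the terminal amide now has its first measured step: a 1.8-fold lower number from compound 1 to compound 4 (0.25 log units; within the scatter), with cyclohexyl in place of cyclopropyl on an amide-type nitrogen. This step stays within the scatter, so compound 1 and compound 4 cannot be ranked, and a six-membered carbon ring can stand at this place where a three-membered one stood without a change that the assay can separate. No recorded evidence bears on this step, so no cause can be assigned to it.

From the compounds shown here alone, whether a phenyl or benzyl group on this nitrogen, or an open-chain group such as tert-butyl, would give a step beyond the scatter remains open. Going by these compounds, the effect of a single change elsewhere in compound 1, such as a morpholine in place of its amine ring, is also open.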